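The compounds below may be only part of what the source reports. "The series", "measured", "known", "first", "only" and "open" are said of these compounds alone.

Series notes. Three compounds have numbers in an ADME assay on Huh-7 cells (Homo sapiens) for cytotoxicity; on this read-out lower numbers stand for higher toxicity in this test and higher numbers for lower toxicity in this test. Compound 1 `O=C(NC(=S)N1CCc2cc(OCc3ccccc3)ccc21)c1ccccc1` gives 45200 nM. Compound 2 `N#Cc1cccc(C(=O)NC(=S)N2CCc3c(OCCCCCOc4ccc(Cl)cc4)cccc32)c1` gives 9750 nM, the lowest of the three numbers. Within the data shown here, compound 3 `O=C(NC(=S)N1CCc2c(OCCCCCOc3ccc(Cl)cc3)cccc21)c1ccc(C(F)(F)F)cc1` gives 32700 nM; the single-point step a 3.4-fold higher number from compound 2 to compound 3 (0.53 log units; beyond the scatter) is the only measured change on the carbonyl carbon, and compound 1 differs from compound 2 in more than one place, so those two values are only compared side by side. The next compound, compound 4 `O=C(NC(=S)N1CCc2c(OCCCCCOc3ccc(Cl)cc3)cccc21)c1ccco1`, keeps the core of compound 2 and changes only the group on the carbonyl carbon: furan-2-yl in place of 3-cyanophenyl on a carbonyl carbon. Among the measured compounds shown here, the one relevant step, from compound 2 to compound 3, moved the number up beyond the scatter; the change to compound 4 also removes the 3-cyanophenyl group and brings in a smaller aromatic ring, so a step upward in the same direction is expected, though with no closer precedent its size is uncertain. The expected step is a 1.8-fold higher number from compound 2 to compound 4 (0.27 log units; within the scatter). Compound 4 is therefore estimated at 18000 nM, within 7000 nM to 45000 nM.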

Compound 4, half-maximal cytotoxic concentration: 4620 nM
Compound 4: the middle estimate sits 3.9-fold (0.59 log units) above what was measured, and the stated range ends above it.
By their numbers in this assay, from the lowest: compound 4; then compound 2; then compounds 3 and 1 (each within the scatter of the next).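

In this assay the group on the carbonyl carbon moves the number in either direction: a 2.1-fold lower number from compound 2 to compound 4 (0.32 log units; beyond the scatter) runs opposite to a 3.4-fold higher number from compound 2 to compound 3 (0.53 log units; beyond the scatter), so leaving the 3-cyanophenyl group does not by itself raise the number. Of the three groups at this place on the shared core, furan-2-yl gives the lowest number, and a 7.1-fold lower number from compound 3 to compound 4 (0.85 log units; beyond the scatter) is the widest step seen here, which shows that the choice of aromatic ring at this place matters to the read-out. Nothing at hand explains the direction or the size of these steps.

On these data alone, how a saturated ring such as piperidine or a simple alkyl chain on the carbonyl carbon would read remains open. Also open, as far as these compounds go, is whether furan-2-yl would give a step of the same direction on the core of compound 1.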